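A few compounds are considered here, and "the series" means these few. Any claim that something is new, unique, unknown or untested is made for them only; others in the source may bear on it.

Measured in a functional assay on B16 cells (Mus musculus) for antiproliferative activity, with a stated time of 72 h; on this read-out higher numbers stand for weaker inhibition and lower numbers for stronger inhibition:
- Compound 1 `OC[C@H]1O[C@@H](n2cnc3c(NCc4ccccc4Cl)ncnc32)[C@H](O)[C@@H]1O`: > 166000 nM
- Compound 2 `Cc1ccc(CNc2ncnc3c2ncn3[C@@H]2O[C@H](CO)[C@@H](O)[C@H]2O)cc1`: "not determined" (no result reported)

The entry for compound 1 is a limit of the assay, not a number. Compound 2 has no result at all, so it has no place on the scale, and the only reference point is the limit of > 166000 nM in this assay, at which 1 of the 2 values shown sits.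

Compound 3 `COc1ccccc1CNc1ncnc2c1ncn2[C@@H]1O[C@H](CO)[C@@H](O)[C@H]1O` keeps the shared core of compound 2. The change is 2-methoxyphenyl in place of 4-methylphenyl on a saturated chain carbon bound to a nitrogen on an aromatic ring.

With no number for compound 2, the size of this step in this assay cannot be read directly. The expectation therefore rests on compound 1 and its limit of > 166000 nM: no step beyond the scatter in either direction, meaning weak inhibition. Compound 3 is expected at 120000 nM, with an estimated range of 25000 nM to 200000 nM.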

Compound 3, half-maximal inhibitory concentration: > 166000 nM
Compound 3 ended at the assay's limit (the forecaster's own chance of this, stated with the estimate: 60%); middle value at least 1.3-fold (0.14 log units) from the limit.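

Compound 1 and compound 3 both end at a limit of the assay and compound 2 has no result, so no new step can be read: the limit of > 166000 nM in this assay, at which 2 of the 3 values shown sit.

The compounds shown leave open whether 2-methoxyphenyl in place of 4-methylphenyl changes inhibition in this assay at all.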